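Dimethylamino on the five-membered ring of compound 2

A few compounds are considered here, and "the series" means these few. Any claim that something is new, unique, unknown or untested is made for them only; others in the source may bear on it.

In a functional assay (aorta) for inhibition, with Rattus norvegicus as the target, with a stated time of 8 days (a higher number here means a weaker inhibitor, a lower number a stronger inhibitor), compound 2 (`FC(F)(F)c1cc(N2CCN(c3ccc(-c4ncns4)nn3)CC2)cc(C(F)(F)F)c1`) gives < 1 nM, which is a limit and not a number. Compound 1 (`Cc1nsc(-c2ccc(N3CCN(c4cc(C(F)(F)F)cc(C(F)(F)F)c4)CC3)nn2)n1`) gives < 0.1 nM, also a limit. Compound 2 therefore has no exact standing in this series.

Compound 3 (`CN(C)c1nsc(-c2ccc(N3CCN(c4cc(C(F)(F)F)cc(C(F)(F)F)c4)CC3)nn2)n1`) carries dimethylamino in place of hydrogen on an aromatic carbon, the same carbon that bears methyl in compound 1: dimethylamino in place of hydrogen on an aromatic carbon.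

Going by the values given here, the one measured step that bears on this change is a step that the two limits leave unreadable from compound 1 to compound 2. Both of its ends are limits, so it gives neither a size nor a direction. No step beyond the scatter is therefore expected, and the expected step is a step that the limit leaves unreadable from compound 2 to compound 3. The estimate for compound 3 is 0.5 nM, with an expected range from 0.05 nM to 5 nM.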

Compound 3, half-maximal inhibitory concentration: 0.1 nM
Estimate against measurement, compound 3: 5.0-fold (0.70 log units) above; measured number inside the range.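

In this assay, going by these compounds alone, compound 3 gives 0.1 nM, the first exact number, so the carbon between two ring nitrogen atoms can carry dimethylamino with a strong inhibitor as the result. Compound 1 gives < 0.1 nM, which is a limit. Dimethylamino in place of methyl gives a number no lower from compound 1 to compound 3 (the limit leaves the size open). The step from compound 2 to compound 3 cannot be read, so dimethylamino in place of hydrogen has neither a size nor a direction yet; compound 3 supplies only a fixed value for later comparisons in the series.

From the compounds shown here alone, whether another amine on this carbon, such as pyrrolidine or morpholine, stays at the level of compound 3 remains open. Also open, going by these compounds, is how hydrogen and methyl on this carbon compare with dimethylamino in exact numbers.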